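A few compounds are considered here, and "the series" means these few. Any claim that something is new, unique, unknown or untested is made for them only; others in the source may bear on it.

Working notes on the series. Compound 1 `CC(C)c1ccc(COc2cc([N+](=O)[O-])ccc2NS(C)(=O)=O)cc1` in an assay on SK-BR-3 cells for inhibition of Aromatase (Homo sapiens) (on this read-out higher numbers stand for weaker inhibition and lower numbers for stronger inhibition), gives 7450 nM. For the measured compounds named here, compound 2 `CN(c1ccc([N+](=O)[O-])cc1OCc1cccc2ccccc12)S(C)(=O)=O` in this assay gives 1170 nM; the two values stand apart, but compound 1 and compound 2 differ in more than one place, so what the pair shows is only that compound 2 sits at the stronger end of the three. Compound 3 `O=C(Nc1ccc([N+](=O)[O-])cc1OCc1ccccc1)c1ccccc1` in this assay gives > 25000 nM, and this is a limit of the assay, not a number. On the values shown, compound 3 therefore stands at the weak edge of the series, at the position described by the limit of > 25000 nM in this assay, at which 1 of the 3 values shown sits.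

Compound 4 `O=C(Nc1ccc([N+](=O)[O-])cc1OCc1ccccc1)c1ccc2ccccc2c1` has not been measured in this assay. Against compound 3 it carries naphthalen-2-yl in place of phenyl on a carbonyl carbon. Going by the values given here, no step between measured compounds isolates this change, so the expectation rests on the limit of compound 3 alone. With the starting point being a limit, the expected step of an at least 1.6-fold lower number from compound 3 to compound 4 (0.22 log units; that floor lies within the scatter) is a modest move toward stronger inhibition, within or close to the scatter, with no firm direction beyond that. Compound 4 is thus estimated at 15000 nM in this assay, with a range from 4000 nM to 50000 nM, and a real chance that only a limit is reported again.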

Compound 4, half-maximal inhibitory concentration: > 25000 nM
Compound 4: only a limit was reported (the forecaster's own chance of this, stated with the estimate: 40%); middle value at least 1.6-fold (0.22 log units) away from the limit.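

Compound 4, like compound 3, is reported in this assay only as a limit, so no step can be read from compound 3 to compound 4: the limit of > 25000 nM in this assay, at which 2 of the 4 values shown sit.
The compounds shown leave open whether naphthalen-2-yl in place of phenyl on a carbonyl carbon changes inhibition at all, in either direction.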